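The source may report more compounds than this note shows. Statements on the series, on what has been measured and on what is new or still open speak of the compounds shown alone.

Of the compounds shown here, three sharing one core have been measured in a functional assay on HCT-8 cells (Homo sapiens) for cytotoxicity; a higher number here means that more compound is needed for the effect, a lower number that less compound is needed. The methoxy compound, compound 1 `COC1=C(C)C(=O)/C(=C(O)/C=C/c2ccc(OC)cc2)C(=O)C1(C)C`, gives 5.6 ug/mL. The hydroxy compound, compound 2 `COC1=C(C)C(=O)/C(=C(O)/C=C/c2ccc(O)cc2)C(=O)C1(C)C`, gives 14.8 ug/mL. The fluoro compound, compound 3 `COC1=C(C)C(=O)/C(=C(O)/C=C/c2ccc(F)cc2)C(=O)C1(C)C`, gives 3.6 ug/mL. The data show a 1.6-fold lower number from compound 1 to compound 3 (0.19 log units; within the scatter), so these two cannot be ranked against each other. They also show a 4.1-fold lower number from compound 2 to compound 3 (0.61 log units; beyond the scatter), which sets compound 3 clearly apart from the hydroxy compound.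

The next compound, compound 4 `COC1=C(C)C(=O)/C(=C(O)/C=C/c2cc(C)cc(C)c2)C(=O)C1(C)C`, changes the aromatic group: 3,5-dimethylphenyl in place of 4-fluorophenyl on a double-bonded chain carbon bound to a double-bonded chain carbon. Among the measured compounds shown here, no measured step tests this group or any methyl on the ring, so the evidence is indirect. The closest guide is a 1.6-fold lower number from compound 1 to compound 3 (0.19 log units; within the scatter), an exchange between two groups that are not hydroxy. For the measured compounds named here, the only steps beyond the scatter involve compound 2, namely a 2.6-fold higher number from compound 1 to compound 2 (0.42 log units; beyond the scatter) and the step to compound 3 already given. Compound 4 has no hydroxy group, so it is expected to fall nearer compound 3 than compound 2, although three compounds make a thin basis for this.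

In this assay the expected change is a 1.3-fold higher number from compound 3 to compound 4 (0.10 log units; within the scatter), an estimated step no larger than the scatter. For compound 4 the estimated value is 4.5 ug/mL, with an expected range from 2 ug/mL to 11 ug/mL.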

Compound 4, concentration for half-maximal effect: 2.9 ug/mL
The estimate for compound 4 lay 1.6-fold (0.19 log units) above the measured number; the range from low to high includes it.
By their numbers in this assay, from the lowest: compounds 4, 3 and 1 (each within the scatter of the next); then compound 2.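

In this assay the exchange of 4-fluorophenyl for 3,5-dimethylphenyl gives a 1.2-fold lower number from compound 3 to compound 4 (0.09 log units; within the scatter) and the exchange of 4-methoxyphenyl for the same group gives a 1.9-fold lower number from compound 1 to compound 4 (0.29 log units; within the scatter), so on this double-bonded chain carbon an aromatic ring carrying two methyl groups cannot be told apart from the rings carrying one fluoro or one methoxy group. The exchange of 4-hydroxyphenyl for 3,5-dimethylphenyl gives a 5.1-fold lower number from compound 2 to compound 4 (0.71 log units; beyond the scatter), which leaves compound 2 as the only one of the four set apart from all the others, while compounds 1, 3 and 4 cannot be ranked among themselves. Nothing available explains these numbers or the separate standing of the hydroxy compound.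

The compounds shown leave open whether any other group on this aromatic ring would move the number beyond the scatter from compounds 1, 3 and 4 in either direction, for example an amine or a carboxylic acid. They also leave open whether a single methyl group would give a number like that of the 3,5-dimethylphenyl compound, or whether a ring other than phenyl could stand at this place.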